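A few compounds are considered here, and "the series" means these few. Any claim that something is new, unique, unknown or untested is made for them only; others in the source may bear on it.

Compound 1 `C#Cc1cccc(Nc2ncnc3ccc(NC(=S)Nc4ccc(S(N)(=O)=O)cc4)cc23)c1` with 13400 nM in a functional assay on NCI-H1975 cells (Homo sapiens) for antiproliferative activity, read by MTT assay, with a stated time of 72 h; a higher number here means a weaker inhibitor, a lower number a stronger inhibitor; compound 2 `NS(=O)(=O)c1ccc(NC(=S)Nc2ccc3ncnc(Nc4cccc(C(F)(F)F)c4)c3c2)cc1` with 7590 nM in this assay.

For the measured compounds named here, these two numbers lie within the usual scatter of each other, so compound 2 cannot be told apart from compound 1 on this assay ; the one step between them, a 1.8-fold lower number from compound 1 to compound 2 (0.25 log units; within the scatter), is a small one. Compound 3 `NS(=O)(=O)c1ccc(NC(=S)Nc2ccc3ncnc(Nc4ccc(F)c(Br)c4)c3c2)cc1` is not yet measured. It differs from compound 2 by 3-bromo-4-fluorophenyl in place of 3-(trifluoromethyl)phenyl on a nitrogen on an aromatic ring, while the shared core and the thiourea-linked sulfonamide part stay the same. Going by the values given here, the only measured step that touches this position is the one from compound 1 to compound 2, and it stayed within the scatter. With nothing more to go on, the step of a 1.3-fold lower number from compound 2 to compound 3 (0.10 log units; within the scatter) is expected to be no larger than the scatter. Compound 3 is therefore estimated at 6000 nM, with a range from 2000 nM to 20000 nM.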

Compound 3, half-maximal inhibitory concentration: 9980 nM
The estimate for compound 3 lay 1.7-fold (0.22 log units) below the measured number; the measured number falls inside the stated range.
By their numbers in this assay, from the lowest: compounds 2, 3 and 1 (each within the scatter of the next).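

In this assay, replacing 3-(trifluoromethyl)phenyl on the nitrogen with 3-bromo-4-fluorophenyl gives a 1.3-fold higher number from compound 2 to compound 3 (0.12 log units; within the scatter), and replacing 3-ethynylphenyl with the same group gives a 1.3-fold lower number from compound 1 to compound 3 (0.13 log units; within the scatter); both steps lie within the scatter. Where the earlier compounds offered a single swap at this position, three different aromatic groups now cannot be told apart, including one that carries two substituents rather than one. Nothing available beyond these numbers helps to explain this result.

On these data alone, whether a group of another kind on this nitrogen, such as 3-aminophenyl, 3-carboxyphenyl or a plain alkyl chain, would move the number beyond the scatter remains open. Also open, as far as these compounds go, is how much the thiourea-linked sulfonamide part, shared by all three compounds, contributes, and whether a urea in place of the thiourea would change the reading.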